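Swapping Furan-2-yl for Pyridin-2-yl on a Weak Series

The source may hold more compounds than are shown below. What is called first, only, known or untested is meant among the compounds shown, and "the series" means these compounds.

Compound 1 `Clc1ccc(-c2cc(-c3ccsc3)nc(-c3ccco3)c2)o1` was tested in a functional assay on HCT-15 cells (Homo sapiens) for cytotoxicity, in the presence of a further agent that is not named here; a lower number here means a stronger inhibitor, a higher number a weaker inhibitor. In this assay compound 1 gives only a limit, > 50000 nM, so no number for it is known. Compound 2 `Clc1ccc(-c2cc(-c3ccco3)nc(-c3cccs3)c2)o1` likewise returns only a limit, > 50000 nM. The step that the two limits leave unreadable from compound 1 to compound 2 therefore cannot be read in either direction. Compound 3 `Clc1ccc(-c2cc(-c3ccoc3)cc(-c3cccs3)n2)cc1`, built from related rings, gives 50000 nM in this assay. Most of the series sits at the limit of > 50000 nM in this assay, at which 2 of the 3 values shown sit, so the whole set stands at or near the edge of what this assay can report.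

Compound 4 `Clc1ccc(-c2cc(-c3ccsc3)nc(-c3ccccn3)c2)o1` differs from compound 1 by pyridin-2-yl in place of furan-2-yl on an aromatic carbon. Among the compounds with values here, no measured step covers an exchange of furan-2-yl for pyridin-2-yl, and the only counted step is unreadable, so the expected size of a step that the limit leaves unreadable from compound 1 to compound 4 is estimated as none beyond the scatter. Compound 4 is expected to give about 60000 nM in this assay, with a range from 20000 nM to 200000 nM, most likely again reported only as a limit.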

Compound 4, half-maximal inhibitory concentration: > 50000 nM
Compound 4 ended at the assay's limit (the forecaster's own chance of this, stated with the estimate: 75%); the middle value is on the limit's open side.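

Compound 1 and compound 4 each return only a limit in this assay, so no step between them can be read in either direction: the limit of > 50000 nM in this assay, at which 3 of the 4 values shown sit.

The compounds shown leave open whether pyridin-2-yl in place of furan-2-yl on this core changes potency at all.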